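This account rests on a few compounds, and the source may have more. Where it says the series, first, only, none or still open, it means among the compounds named here.

Three compounds share one core and differ only in the group on a saturated chain carbon bound to a saturated ring carbon. In a functional assay on HUVEC cells (Homo sapiens), read by scintillation counting and thymidine incorporation, with a stated time of 24 h (on this read-out lower numbers stand for stronger inhibition and higher numbers for weaker inhibition), compound 1 `CCC(C)n1ncn(-c2ccc(N3CCN(c4ccc(OC[C@@H]5CO[C@@](CBr)(c6ccc(Cl)cc6Cl)O5)cc4)CC3)cc2)c1=O`, with bromo there, gives 569 nM. Compound 2 `CCC(C)n1ncn(-c2ccc(N3CCN(c4ccc(OC[C@@H]5CO[C@@](CC6CCCC6)(c6ccc(Cl)cc6Cl)O5)cc4)CC3)cc2)c1=O`, with cyclopentyl, gives 512 nM. Compound 3 `CCC(C)n1ncn(-c2ccc(N3CCN(c4ccc(OC[C@@H]5CO[C@@](CN6CCNCC6)(c6ccc(Cl)cc6Cl)O5)cc4)CC3)cc2)c1=O`, with piperazin-1-yl, gives 608 nM, which places it level with the other two, as a 1.1-fold higher number from compound 1 to compound 3 (0.03 log units; within the scatter) and a 1.2-fold higher number from compound 2 to compound 3 (0.07 log units; within the scatter) show.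

Compound 4 `CCC(C)n1ncn(-c2ccc(N3CCN(c4ccc(OC[C@@H]5CO[C@@](Cn6cnc(C)n6)(c6ccc(Cl)cc6Cl)O5)cc4)CC3)cc2)c1=O` has not yet been measured. It changes the same place: 3-methyl-1H-1,2,4-triazol-1-yl in place of piperazin-1-yl on a saturated chain carbon bound to a saturated ring carbon. A five-membered aromatic ring thus replaces a six-membered non-aromatic ring.

All three measured steps are swaps at this place, and the third, a 1.1-fold lower number from compound 1 to compound 2 (0.05 log units; within the scatter), is just as small. Among the compounds with values here, none of the measured groups is an aromatic ring, so this evidence is indirect. No step beyond the scatter is therefore expected in this assay. The expected change is a 1.1-fold lower number from compound 3 to compound 4 (0.04 log units; within the scatter). The estimated value for compound 4 is 550 nM, with an expected range from 300 nM to 1000 nM.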

Compound 4, half-maximal inhibitory concentration: 272 nM
Beside the measured number, compound 4's estimate is 2.0-fold (0.31 log units) above it; the whole stated range lies above it.
By their numbers in this assay, from the lowest: compounds 4, 2, 1 and 3 (each within the scatter of the next, the first and the last beyond it).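

Within the data shown here, this position is less indifferent to its group than the first three compounds suggested: in this assay, the 3-methyl-1H-1,2,4-triazol-1-yl group gives a 2.2-fold lower number from compound 3 to compound 4 (0.35 log units; beyond the scatter) and a 2.1-fold lower number from compound 1 to compound 4 (0.32 log units; beyond the scatter) as the first steps at this place beyond the scatter. The effect is modest and does not separate compound 4 from every other group, as a 1.9-fold lower number from compound 2 to compound 4 (0.27 log units; within the scatter) stays within the scatter and leaves compound 4 level with compound 2. Nothing in the data shown explains these steps.

The compounds shown leave open whether the lower number goes with the aromatic ring, with the methyl on it or with the ring nitrogens. Comparing the unsubstituted 1H-1,2,4-triazol-1-yl, imidazol-1-yl and phenyl groups at this place would help to separate these three readings.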